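A few compounds are considered here, and "the series" means these few. Any claim that something is new, unique, unknown or untested is made for them only; others in the source may bear on it.

Among the compounds with values here, in an ADME assay on MT4 cells (Homo sapiens) for cytotoxicity, read by MTT assay, with a stated time of 4 days (on this read-out lower numbers stand for higher toxicity in this test and higher numbers for lower toxicity in this test), compound 1 `O=C(COc1cccc2ccccc12)N/N=C/c1ccc(Br)cc1` gives 106 ug/mL and stands highest of the two numbers so far. Compound 2 `COc1cc(/C=N/NC(=O)COc2cccc3ccccc23)cc(OC)c1OC` gives 13.4 ug/mL and lies lower, beyond the usual scatter. Within the data shown here, compound 3 `O=C(COc1cccc2ccccc12)N/N=C/c1ccccc1` has no measurement yet. Compound 3 differs from compound 1 in one place (hydrogen in place of bromo on an aromatic carbon) with hydrogen in place of bromo on an aromatic carbon, para to a large group. The rest of the structure stays the same. Among the measured compounds shown here, no measured pair isolates this change, so the expectation has little support and the range is kept wide. In this assay a small move toward a lower number is expected, and the expected step of a 1.6-fold lower number from compound 1 to compound 3 (0.21 log units; within the scatter) stays within the usual scatter. Compound 3 is estimated at 65 ug/mL with an expected range of 20 ug/mL to 180 ug/mL in this read-out.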

Compound 3, half-maximal cytotoxic concentration: >= 96.6 ug/mL
Compound 3: only a limit was reported (the forecaster's own chance of this, stated with the estimate: 15%); at least 1.4-fold (0.17 log units) between middle value and limit.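

In this assay, within the data shown here, compound 3 gives >= 96.6 ug/mL, which is a limit and not a number, so no step from compound 1 to compound 3 can be read. The compounds shown leave open whether going from 4-bromophenyl to phenyl changes this read-out, and in which direction.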